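Shortening the ether substituent on a biphenyl aniline series

The source may report more compounds than this note shows. Statements on the series, on what has been measured and on what is new or still open speak of the compounds shown alone.

The series rests on a shared core carrying a hydroxybenzyl amine on a biphenyl, and the compounds are compared in a functional assay on Jurkat cells (Homo sapiens) for activation, with a stated time of 24 h; a lower number here means that less compound is needed, a higher number that more compound is needed for the effect. The unsubstituted parent, compound 1 `Oc1ccccc1CNc1ccc(-c2ccccc2)cc1`, gives 1820 nM in this assay. Compound 2 `Oc1ccccc1CNc1ccc(-c2cccc(OCc3ccccc3)c2)cc1` carries a benzyloxy group on the outer ring and is reported in this assay as "not active" (no number reported), so for compound 2 no single number stands, only the report that no activation was reached; it cannot be placed on a scale against compound 1 beyond that.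

Compound 3 `CCOc1cccc(-c2ccc(NCc3ccccc3O)cc2)c1` keeps the same core and differs from compound 2 by methyl in place of phenyl on a saturated chain carbon bound to an oxygen on an aromatic ring. Within the data shown here, since compound 2 offers no number, no step can be counted for it. A return toward the potency of compound 1 is possible, but the outcome in this assay remains uncertain in either direction.

Compound 3 is expected to give about 3500 nM in this assay, with a range from 900 nM to 20000 nM.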

Compound 3, half-maximal effective concentration: "not active" (no number reported)
Nothing numeric was reported for compound 3; no gap can be computed for the estimate.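

In this assay compound 3, like compound 2, is reported as "not active", so no step can be read between them. The compounds shown leave open whether any ether substituent on the outer ring keeps the activation compound 1 gives at 1820 nM in this series. No evidence on hand bears on this result.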